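The source may report more compounds than this note shows. Statements on the series, on what has been measured and on what is new or still open speak of the compounds shown alone.

Measured in a functional assay on HT-1080 cells (Homo sapiens), read by transwell migration, with a stated time of 24 h, tested at 0.1 uM; on this read-out higher numbers stand for a weaker effect at the one concentration tested and lower numbers for a stronger effect:

compound 1 `CC(=O)OCc1ccc2oc(=O)c(C(=O)Oc3cccc(Br)c3)cc2c1` — 39.5%
compound 2 `CC(=O)OCc1ccc2oc(=O)c(C(=O)Sc3ccccc3)cc2c1` — 89.5%
compound 3 `CC(=O)OCc1ccc2oc(=O)c(C(=O)Nc3cccc(Cl)c3)cc2c1` — 79.6%

Compound 1 stands lowest of the three numbers in this assay, which on this read-out is the strongest effect of the set. The two steps away from it both change the group on the carbonyl carbon: a number 50 percentage points higher from compound 1 to compound 2 (beyond the scatter) and a number 40.1 percentage points higher from compound 1 to compound 3 (beyond the scatter), both beyond the scatter and large. Between compound 2 and compound 3 the step is a number 9.9 percentage points lower from compound 2 to compound 3 (within the scatter), within the scatter.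

Compound 4 `CCCC(=O)OCc1ccc2oc(=O)c(C(=O)Oc3cccc(Br)c3)cc2c1` keeps the 3-bromophenoxy group of compound 1 and differs only at the acetyl end: ethyl in place of hydrogen on a saturated chain carbon bound to a carbonyl carbon. Going by the values given here, none of the measured steps touches this place; all three changes so far sit on the carbonyl carbon, so there is no measured step that bears directly on the change from compound 1 to compound 4. With the part that drove the large steps held constant, the expectation is a step within the scatter, with no direction claimed beyond it; the estimated step is a number 5.5 percentage points higher from compound 1 to compound 4 (within the scatter). Compound 4 is therefore expected to give about 45% in this assay, with a range of 25% to 70% that allows for the lack of any measured step at this position.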

Compound 4, a percentage reported as activity, at one concentration (the size of the read-out at that concentration, not a potency): 88.6%
Compound 4: middle estimate off by 43.6 percentage points, on the low side, and the stated range ends below it.
By their numbers in this assay, from the lowest: compound 1; then compounds 3, 4 and 2 (each within the scatter of the next).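

The acetyl end is not a neutral place in this assay and responds to a small change in the chain. With the 3-bromophenoxy group held constant, ethyl in place of hydrogen on a saturated chain carbon bound to a carbonyl carbon gives a number 49.1 percentage points higher from compound 1 to compound 4 (beyond the scatter) and so counts as a large step. Among the pairs shown, large steps now follow both from replacing the 3-bromophenoxy group on the carbonyl carbon and from going from acetyl to propylcarbonyl, so the low number of compound 1 appears only with both of its groups in place, and no data shown account for the size of this step.

The compounds shown leave open whether the response along this chain is gradual or abrupt, since a propionyl group, a longer chain such as pentanoyl, a branched isobutyryl group or a free hydroxymethyl group could fall close to either compound 1 or compound 4. They also leave open whether propylcarbonyl in place of acetyl would shift the number of the anilide compound 3 or the phenylsulfanyl compound 2 in the same way.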